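A Bromophenyl Replaces a Dichlorophenyl in Compound 3

The compounds below may be only part of what the source reports. "The series", "measured", "known", "first", "only" and "open" are said of these compounds alone.

Compound 2 `O=C(/C=C\c1ccc(Cl)cc1Cl)N1N=C(c2ccncc2)OC1c1c[nH]c2ccccc12` is the starting point. In an ADME assay on PANC-1 cells (Homo sapiens) for cytotoxicity, read by MTT assay, with a stated time of 48 h (on this read-out higher numbers stand for weaker inhibition of growth and lower numbers for stronger inhibition of growth), compound 2 gives > 30 ug/mL, which is a limit of the assay rather than a number. Compound 1 `O=C(/C=C\c1ccccc1O)N1N=C(c2ccncc2)OC1c1c[nH]c2ccccc12` differs from compound 2 in one place. In this assay compound 1 gives > 30 ug/mL, again a limit of the assay and not a number. Both values sit at the limit of > 30 ug/mL in this assay, at which 2 of the 2 values shown sit, and so the step that the two limits leave unreadable from compound 1 to compound 2 cannot be read in either direction or size.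

Compound 3 `O=C(/C=C\c1cccc(Br)c1)N1N=C(c2ccncc2)OC1c1c[nH]c2ccccc12` carries 3-bromophenyl in place of 2,4-dichlorophenyl on a double-bonded chain carbon bound to a double-bonded chain carbon. Among the compounds with values here, the one measured step concerns an exchange on the same aryl group, yet its size is unreadable, so it gives no direction for this change. The step that the limit leaves unreadable from compound 2 to compound 3 is expected to be no larger than the scatter. Compound 3 is estimated at 40 ug/mL, within 15 ug/mL to 100 ug/mL, and is expected most likely to return only a limit again.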

Compound 3, concentration for 50% growth inhibition: > 30 ug/mL
Compound 3: a limit, no number; the forecaster's own chance of this, stated with the estimate: 75%; the middle value is on the limit's open side.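

In this assay compound 3 gives > 30 ug/mL, a limit of the assay and not a number. Within the data shown here, no step among compound 1, compound 2 and compound 3 can be read. The compounds shown leave open whether any exchange on this aryl group changes growth inhibition at all.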